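Thiophen-2-yl in place of (pyrrolidin-1-yl)carbonyl

This account rests on a few compounds, and the source may have more. Where it says the series, first, only, none or still open, it means among the compounds named here.

In a physicochemical assay for lipophilicity, using the shake flask method, measured as octanol-water partition, at pH 7.4 (a higher number here means a more lipophilic compound, a lower number a more polar compound), compound 1 `CC(C)n1cc(-c2ccnc3[nH]c(C4CCNCC4)cc23)ccc1=O` gives -0.2 and compound 2 `CC(C)n1cc(-c2ccnc3[nH]c(C4CCN(CC(=O)N5CCCC5)CC4)cc23)ccc1=O` gives 2.1 as the higher of the two numbers. Compound 3 `CC(C)n1cc(-c2ccnc3[nH]c(C4CCN(Cc5cccs5)CC4)cc23)ccc1=O` carries thiophen-2-yl in place of the (pyrrolidin-1-yl)carbonyl of compound 2, on a saturated chain carbon bound to an amine nitrogen in a ring (thiophen-2-yl in place of (pyrrolidin-1-yl)carbonyl on a saturated chain carbon bound to an amine nitrogen in a ring). Going by the values given here, one measured step bears on this: the large a number 2.30 log units higher from compound 1 to compound 2 (beyond the scatter) upon adding ((pyrrolidin-1-yl)carbonyl)methyl on that nitrogen. Compound 3 keeps a substituent there, so a much smaller, upward change is expected, estimated as a number 0.50 log units higher from compound 2 to compound 3 (beyond the scatter) in this assay overall. In this assay compound 3 is estimated at 2.6 with an expected range (2 to 3.2).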

Compound 3, distribution coefficient: 3.4
Beside the measured number, compound 3's estimate is 0.80 log units below it; measured number above the stated range.
By their numbers in this assay, from the lowest: compound 1; then compound 2; then compound 3.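

In this assay, going by these compounds alone, the earlier compounds showed only that a substituent on the amine nitrogen in a ring raises the number; this result shows that the group on the saturated chain carbon also counts, with a number 1.30 log units higher from compound 2 to compound 3 (beyond the scatter). Against the free amine, (thiophen-2-yl)methyl gives a number 3.60 log units higher from compound 1 to compound 3 (beyond the scatter), so the two substituents on this nitrogen are not interchangeable in this measurement. No measurement at hand accounts for the difference. The compounds shown leave open whether the step follows the thiophene ring or the loss of the carbonyl, and where a phenyl ring or a plain methyl on that nitrogen would fall.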